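This account rests on a few compounds, and the source may have more. Where it says the series, first, only, none or still open, it means among the compounds named here.

In a functional assay on KYSE-70 cells for antiproliferative activity against KYSE-70 cell line (Homo sapiens), read by MTT assay, with a stated time of 72 h (on this read-out higher numbers stand for weaker inhibition and lower numbers for stronger inhibition), compound 1 (`O=C(Nc1cccc(F)c1)c1cc(=O)[nH]c2cc(-c3cccc(F)c3)ccc12`) gives 12000 nM. Compound 2 (`O=C(Nc1cccc(F)c1)c1cc(=O)[nH]c2cc(C3CC3)ccc12`) gives > 20000 nM, which is a limit and not a number. Compound 3 (`O=C(Nc1cccc(F)c1)c1cc(=O)[nH]c2cc(-c3ccncc3)ccc12`) gives > 20000 nM, again only a limit, and this is the limit of > 20000 nM in this assay, at which 2 of the 3 values shown sit. Compound 4 (`O=C(Nc1cccc(F)c1)c1cc(=O)[nH]c2cc(C3=CCOCC3)ccc12`) alters compound 3 at one place: a group of 6 heavy atoms (5 carbon, 1 oxygen; one six-membered non-aromatic ring with 1 hetero atom) in place of a group of 6 heavy atoms (5 carbon, 1 nitrogen; one six-membered aromatic ring with 1 hetero atom), on an aromatic carbon. Within the data shown here, three measured steps bear on this change. They are an at least 1.6-fold higher number from compound 1 to compound 2 (0.22 log units; that floor lies within the scatter), an at least 1.6-fold higher number from compound 1 to compound 3 (0.22 log units; that floor lies within the scatter) and a step that the two limits leave unreadable from compound 2 to compound 3. None of them shows a change beyond the scatter, so no step beyond the scatter is expected here, in either direction. The expected step is a number no higher from compound 3 to compound 4 (the limit leaves the size open). In this assay, compound 4 is estimated at 20000 nM, with an expected range from 9000 nM to 40000 nM.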

Compound 4, half-maximal inhibitory concentration: 10500 nM
Compound 4: the middle estimate sits 1.9-fold (0.28 log units) above what was measured; measured number inside the range.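

In this assay, the non-aromatic oxygen ring gives a readable number at this position, but the steps from the two groups that gave only limits are floors: an at least 1.9-fold lower number from compound 3 to compound 4 (0.27 log units; that floor lies within the scatter) and an at least 1.9-fold lower number from compound 2 to compound 4 (0.27 log units; that floor lies within the scatter). Set against 3-fluorophenyl, the same ring shows a 1.1-fold lower number from compound 1 to compound 4 (0.06 log units; within the scatter), so an aromatic ring is not required here to reach the level of that group. Neither floor gives a size because two compounds stand only at a limit: the limit of > 20000 nM in this assay, at which 2 of the 4 values shown sit.

On these data alone, how a tetrahydropyran ring without the double bond, a morpholine or a piperidine would read at this position remains open. So does the true size of the two floors.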